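Phenyl for cyclopropyl on the chain carbon of compound 2

The compounds below may be only part of what the source reports. "The series", "measured", "known", "first", "only" and "open" are said of these compounds alone.

Three members of the series have numbers in a functional assay on the whole organism (plasma, strain Sprague-Dawley) with Rattus norvegicus as the target, with a stated time of 2 h, at a dose of 100 mg/kg by the oral route; on this read-out higher numbers stand for a stronger effect at the one dose given and lower numbers for a weaker effect. Compound 1 `Cc1ccc(C(/N=C2\CCCCCN2)C2CC2)c(C)c1` gives 56% in this assay. Compound 2 `c1csc(C(/N=C2\CCCCCCN2)C2CC2)c1` gives 50% in this assay. Compound 3 `c1ccc(C(/N=C2\CCCCCN2)c2ccco2)cc1` gives 52% in this assay. Among the compounds with values here, the three numbers sit within the usual scatter of one another, so compound 2 stands level with compound 1 and compound 3 on the numbers so far, and no ordering among them can be drawn.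

Compound 4 `c1ccc(C(/N=C2\CCCCCCN2)c2cccs2)cc1` has not yet been measured in this assay. It differs from compound 2 in one place: phenyl in place of cyclopropyl on a saturated chain carbon bound to an aromatic carbon and a double-bonded nitrogen. Within the data shown here, no single-change step between measured compounds is available to size this exchange. Compound 3, which already carries a phenyl on the saturated chain carbon next to a different aromatic ring and a different core, gives 52%, a number within the scatter of compound 2, which is the only hint that the phenyl group by itself does not move the read-out far.

On that basis the step of a number 2 percentage points higher from compound 2 to compound 4 (within the scatter) is expected to stay within the scatter, with no direction assigned. Compound 4 is therefore estimated at 52% in this assay, with a range from 35% to 68%.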

Compound 4, a percentage reported as inhibition, in the whole organism at one dose (the size of the read-out at that dose, not a potency): 41%
Estimate against measurement, compound 4: 11 percentage points above; measured number inside the range.
By their numbers in this assay, from the lowest: compounds 4, 2, 3 and 1 (each within the scatter of the next, the first and the last beyond it).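

Within the data shown here, this is the first single-place step: with phenyl in place of cyclopropyl on a saturated chain carbon bound to an aromatic carbon and a double-bonded nitrogen, this assay gives a number 9 percentage points lower from compound 2 to compound 4 (within the scatter). At this place, then, a three-membered non-aromatic ring of carbon only and a six-membered aromatic ring of carbon only are not told apart by this read-out at the one dose given, even though the entering group carries 6 heavy atoms against 3 for the group that leaves. Nothing at hand bears on what lies behind this step, in either direction.

Still open, on these data alone, is whether the exchange reads the same way on the core of compound 1 or compound 3, since this one step comes from a single pair with a single aromatic partner on the chain carbon. Also open, as far as these compounds go, is how this place responds to groups of another kind, such as an amine or a carboxylic acid on a longer chain in place of the ring, which would test whether a ring is needed there at all.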